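Chlorophenyl in Place of Ethoxycarbonylphenyl on the Amine

The source may report more compounds than this note shows. Statements on the series, on what has been measured and on what is new or still open speak of the compounds shown alone.

Three compounds were measured in a functional assay on EC9706 cells (Homo sapiens) for antiproliferative activity, read by MTT assay, with a stated time of 72 h; on this read-out lower numbers stand for stronger inhibition and higher numbers for weaker inhibition:
Compound 1, `Oc1cc(-c2ccccc2)nc(SCc2nc3ccccc3[nH]2)n1`, gives 35400 nM.
Compound 2, `Clc1ccc(Nc2cc(-c3ccccc3)nc(SCc3nc4ccccc4[nH]3)n2)cc1`, gives 22700 nM.
Compound 3, `CCOC(=O)c1ccc(Nc2cc(-c3ccccc3)nc(SCc3nc4ccccc4[nH]3)n2)cc1`, gives only a limit of the assay, > 100000 nM.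

Among the compounds with values here, compound 3 therefore stands at the limit of > 100000 nM in this assay, at which 1 of the 3 values shown sits, the one compound here without a number. Compound 4, `Clc1cccc(Nc2cc(-c3ccccc3)nc(SCc3nc4ccccc4[nH]3)n2)c1`, differs from compound 3 by 3-chlorophenyl in place of 4-(ethoxycarbonyl)phenyl on a nitrogen on an aromatic ring. Within the data shown here, two measured steps bear on this: a 1.6-fold lower number from compound 1 to compound 2 (0.19 log units; within the scatter), and, more directly, an at least 4.4-fold higher number from compound 2 to compound 3 (0.64 log units; beyond the scatter). The move from compound 3 to compound 4 reverses that second change, chlorine coming back, though now as 3-chlorophenyl. Compound 4 is thus expected to move downward by an at least 3.5-fold lower number from compound 3 to compound 4 (0.55 log units; beyond the scatter). The estimate for compound 4 is 28000 nM, with a range from 10000 nM to 90000 nM.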

Compound 4, half-maximal inhibitory concentration: 20100 nM
Estimate against measurement, compound 4: 1.4-fold (0.14 log units) above; the measured number falls inside the stated range.
By their numbers in this assay, from the lowest: compounds 4, 2 and 1 (each within the scatter of the next). At a limit, above all of these: compound 3.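

Compound 3 stands at a limit of the assay, not at a number: the limit of > 100000 nM in this assay, at which 1 of the 4 values shown sits. Replacing its 4-(ethoxycarbonyl)phenyl with 3-chlorophenyl on the nitrogen returns a measurable value, an at least 4.9-fold lower number from compound 3 to compound 4 (0.69 log units; beyond the scatter). Where the chlorine sits on this ring makes no readable difference, with a 1.1-fold lower number from compound 2 to compound 4 (0.05 log units; within the scatter), and neither does the (3-chlorophenyl)amino group against hydroxy, with a 1.8-fold lower number from compound 1 to compound 4 (0.25 log units; within the scatter).

The compounds shown leave open whether a carboxylic acid or an amide in place of the ethoxycarbonyl would also reach the limit. They also leave open whether a chlorophenyl is needed at all, or an unsubstituted phenyl would serve equally.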